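Shortening the ethoxy chain: notes on compound 4

The source may report more compounds than this note shows. Statements on the series, on what has been measured and on what is new or still open speak of the compounds shown alone.

Three compounds of the series have numbers in a functional assay on A-375 cells (Homo sapiens) for antiproliferative activity, read by MTT assay, with a stated time of 24 h, tested at 0.02 ug/mL; on this read-out higher numbers stand for a stronger effect at the one concentration tested and lower numbers for a weaker effect. Compound 1 `Cc1ccc2nc(C(=O)Nc3c(F)cc(-c4cccc(F)c4)cc3F)c(C)c(C(=O)O)c2c1` gives 0.02%, compound 2 `CCc1ccc2nc(C(=O)Nc3c(F)cc(-c4cccc(F)c4)cc3F)c(C)c(C(=O)O)c2c1` gives -0.12%, and compound 3 `CCOc1ccc2nc(C(=O)Nc3c(F)cc(-c4cccc(F)c4)cc3F)c(C)c(C(=O)O)c2c1` gives 1.02%. Compound 3 carries the highest of the three numbers, but its lead is small: a number 1 percentage points higher from compound 1 to compound 3 (within the scatter) and a number 1.1 percentage points higher from compound 2 to compound 3 (within the scatter), so the three sit together within the scatter.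

Compound 4 `COc1ccc2nc(C(=O)Nc3c(F)cc(-c4cccc(F)c4)cc3F)c(C)c(C(=O)O)c2c1` is not yet measured. It differs from compound 3 by hydrogen in place of methyl on a saturated chain carbon bound to an oxygen on an aromatic ring. The step that bears most directly on this change is the one in which a methyl was added to a chain carbon, a number 0.1 percentage points lower from compound 1 to compound 2 (within the scatter), which produced nothing beyond the scatter. The change from ethyl to ethoxy on the aromatic carbon, a number 1.1 percentage points higher from compound 2 to compound 3 (within the scatter), was likewise flat. Going by the values given here, nothing among the measured steps suggests that trimming the ethoxy to methoxy should move the read-out beyond the scatter. Compound 4 is therefore expected to give 0.5%, in the range -3% to 4%, which means an expected step of a number 0.5 percentage points lower from compound 3 to compound 4 (within the scatter).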

Compound 4, a percentage reported as inhibition, at one concentration (the size of the read-out at that concentration, not a potency): 0.13%
For compound 4 the middle estimate is 0.4 percentage points above the measured one; low and high end bracket the measured number.
By their numbers in this assay, from the lowest: compounds 2, 1, 4 and 3 (each within the scatter of the next).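

Shortening ethoxy to methoxy gives a direct test of the change at this position, and the reading in this assay stays within the scatter (a number 0.9 percentage points lower from compound 3 to compound 4 (within the scatter)). Methoxy on this aromatic carbon also stands level with ethyl (a number 0.3 percentage points higher from compound 2 to compound 4 (within the scatter)) and with methyl (a number 0.1 percentage points higher from compound 1 to compound 4 (within the scatter)), so none of the four groups shown separates from the others. Removing or adding a methyl at the end of a chain now reads alike in both settings: the same change on two cores in this assay, a number 0.1 percentage points lower (within the scatter) from compound 1 to compound 2 and a number 0.9 percentage points higher (within the scatter) from compound 4 to compound 3, 1 percentage points apart, within the scatter of two such steps.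

All four compounds sit together at the one concentration tested, so the compounds shown cannot tell whether this position tolerates change or whether the read-out leaves no room for a difference at this concentration. On these data alone, whether an amine, a carboxylic acid or a longer chain such as butoxy on this aromatic carbon would lift the reading beyond the scatter remains open.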